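The source may report more compounds than this note shows. Statements on the series, on what has been measured and on what is new or still open speak of the compounds shown alone.

Among the compounds with values here, three compounds sharing one core went into a functional assay on CWR22R cells (Homo sapiens) for antiproliferative activity, read by CCK-8 assay, with a stated time of 6 days (on this read-out higher numbers stand for weaker inhibition and lower numbers for stronger inhibition), and only one returned a number. Compound 1 `C[C@@H](Cn1ccc(-c2ccc(C#N)c(Cl)c2)n1)NC(=O)c1ccccc1F` stands as "not determined" (no result reported). Compound 2 `COC(=O)/C=C/C(=O)N[C@@H](C)Cn1ccc(-c2ccc(C#N)c(Cl)c2)n1` stands as "not determined" (no result reported). Compound 3 `C[C@@H](Cn1ccc(-c2ccc(C#N)c(Cl)c2)n1)Nc1cccnc1` gives 21600 nM, which leaves it with no measured neighbour to be ranked against.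

The next compound to be tested is compound 4 `C[C@@H](Cn1ccc(-c2ccc(C#N)c(Cl)c2)n1)Nc1cncnc1`. It keeps the rest of compound 3 and carries pyrimidin-5-yl in place of pyridin-3-yl on an amine nitrogen. No measured step among these compounds shows what this exchange does, so the expectation rests only on compound 3 at 21600 nM and on the structural change itself. A slight weakening is expected, one that may not rise beyond the usual scatter, and the estimated move is a 1.4-fold higher number from compound 3 to compound 4 (0.14 log units; within the scatter). For compound 4 the estimated value is 30000 nM, with an expected range from 12000 nM to 70000 nM.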

Compound 4, half-maximal inhibitory concentration: > 30000 nM
Compound 4: no number, only a limit (the forecaster's own chance of this, stated with the estimate: 25%); the middle value lies on the limit itself.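

In this assay compound 4 gives > 30000 nM, which is a limit of the assay and not a number. Pyrimidin-5-yl in place of pyridin-3-yl on an amine nitrogen is the only exchange here that can be read, and it comes out as an at least 1.3-fold higher number from compound 3 to compound 4 (0.14 log units; that floor lies within the scatter), so the change has a floor but no upper end, and that floor does not separate the two compounds beyond the usual scatter. The step therefore rests on a limit: the limit of > 30000 nM in this assay, at which 1 of the 4 values shown sits.

The compounds shown leave open how far the true value of compound 4 lies from that of compound 3. They also leave open how a phenyl ring or a simple ethyl chain would read on the same amine nitrogen, and so whether any group there gives a markedly lower number.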